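Shifting a Hydroxyl Group from Compound 2 to Compound 3

This account rests on a few compounds, and the source may have more. Where it says the series, first, only, none or still open, it means among the compounds named here.

Compound 1 `COc1cc(OC)c(C(=O)/C=C/c2ccc(O)cc2)c(O)c1CC=C(C)C`: 11800 nM
Compound 2 `COc1cc(O)c(CC=C(C)C)c(O)c1C(=O)/C=C/c1cccc(O)c1`: 4800 nM

In a functional assay on HeLa cells (Homo sapiens) for cytotoxicity, read by MTT assay (a lower number here means a stronger inhibitor, a higher number a weaker inhibitor), compound 2 gives 4800 nM, the lower of the two numbers and so the stronger result, a gap from compound 1 that lies beyond the usual scatter. The next molecule is compound 3 `COc1cc(O)c(CC=C(C)C)c(O)c1C(=O)/C=C/c1ccccc1O`. The change is 2-hydroxyphenyl in place of 3-hydroxyphenyl on a double-bonded chain carbon bound to a double-bonded chain carbon, with 2-hydroxyphenyl replacing 3-hydroxyphenyl on a double-bonded chain carbon bound to a double-bonded chain carbon. Among the measured compounds shown here, no measured pair isolates a change like this one, so any prediction is uncertain. In this assay, the expected change a 1.3-fold higher number from compound 2 to compound 3 (0.10 log units; within the scatter) is small, with no shift beyond the scatter. For compound 3, the estimated value is 6000 nM, within a range of 2500 nM to 15000 nM.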

Compound 3, half-maximal inhibitory concentration: 5900 nM
Beside the measured number, compound 3's estimate is 1.0-fold (0.01 log units) above it; the measured number falls inside the stated range.
By their numbers in this assay, from the lowest: compounds 2, 3 and 1 (each within the scatter of the next, the first and the last beyond it).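

In this assay putting 2-hydroxyphenyl in place of 3-hydroxyphenyl on a double-bonded chain carbon bound to a double-bonded chain carbon gives a 1.2-fold higher number from compound 2 to compound 3 (0.09 log units; within the scatter) and so the two hydroxyl placements cannot be told apart here. Among the compounds shown here, compound 1 and compound 2 differ in more than one place, so only this pair gives a reading on this single change. Nothing available explains the result.

Still open, from the compounds shown here alone, is whether this ring needs a hydroxyl at all. An unsubstituted phenyl, or an amine or a carboxylic acid in place of the hydroxyl, could answer that.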